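This account rests on a few compounds, and the source may have more. Where it says the series, first, only, none or still open, it means among the compounds named here.

Measured so far:
Compound 1 `COc1ccc(CCCCCCCCOc2ccc(CSc3cccc(C(=O)O)c3)nc2/C=C/C(=O)O)cc1` — in an assay for binding affinity to leukotriene B4 receptor 1 (Homo sapiens) (a lower number here means a stronger inhibitor, a higher number a weaker inhibitor), compound 1 gives 80 nM.
Compound 2 `COc1ccc(CCCCCCCCOc2ccc(CSc3cccc(NS(=O)(=O)C(F)(F)F)c3)nc2/C=C/C(=O)O)cc1` — in this assay compound 2 gives 284 nM.

Compound 2 stands at the higher of the two numbers, the weaker binder; its nearest neighbour is compound 1, and the step of a 3.6-fold higher number from compound 1 to compound 2 (0.55 log units; beyond the scatter) lies beyond the scatter. Compound 3 `COc1ccc(CCCCCCCCOc2ccc(CSc3cccc(OC)c3)nc2/C=C/C(=O)O)cc1` differs from compound 2 by methoxy in place of ((trifluoromethyl)sulfonyl)amino on an aromatic carbon. Among the measured compounds shown here, only one measured step bears on this change: a 3.6-fold higher number from compound 1 to compound 2 (0.55 log units; beyond the scatter) shows that replacing the carboxy group of compound 1 already weakened binding. For the measured compounds named here, no measured compound carries a methoxy at this place, so the effect of the entering group is not known from these data. The expectation is that compound 3 moves further in the same direction, by a modest step of a 4.2-fold higher number from compound 2 to compound 3 (0.63 log units; beyond the scatter) in this assay. For compound 3 the estimate in this assay is 1200 nM, with a range from 250 nM to 6000 nM.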

Compound 3, inhibition constant: 192 nM
Estimate against measurement, compound 3: 6.3-fold (0.80 log units) above; the whole stated range lies above it.
By their numbers in this assay, from the lowest: compound 1; then compounds 3 and 2 (each within the scatter of the next).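

In this assay, methoxy in place of ((trifluoromethyl)sulfonyl)amino gives a 1.5-fold lower number from compound 2 to compound 3 (0.17 log units; within the scatter), so these two groups cannot be told apart at this aromatic carbon, even though methoxy has no hydrogen-bond donor. Methoxy in place of carboxy gives a 2.4-fold higher number from compound 1 to compound 3 (0.38 log units; beyond the scatter), which is a modest loss of about the same kind as the one already seen with the ((trifluoromethyl)sulfonyl)amino group. Of the three groups, carboxy therefore stands alone, with the lowest number and steps beyond the scatter to both others, but nothing measured here explains why.

As far as these compounds go, it remains open how an amine, a hydroxyl or a tetrazole on this aromatic carbon would compare with carboxy. Also open, from the compounds shown here alone, is whether a carboxylic acid held on a longer chain, such as an acetic acid group, would keep the lower number.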